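Capping the Phenol: From Compound 3 to Compound 4

A few compounds are considered here, and "the series" means these few. Any claim that something is new, unique, unknown or untested is made for them only; others in the source may bear on it.

Compound 1 `CC(C)(C)C1=NN(c2ccccc2F)C(c2ccc(O)cc2)C1` gives 57.6% in an assay on isolated protein for inhibition of protein kinase C zeta type (Homo sapiens), with a stated time of 4 min, tested at 62.5 uM; a higher number here means more inhibition at the concentration tested (going by the name of the read-out), a lower number less inhibition. Compound 2 `Oc1ccc(C2CC(c3ccccc3)=NN2c2ccc(Cl)cc2)cc1` gives 95.6%, and compound 3 `Oc1ccc(C2CC(c3ccccc3O)=NN2c2ccc(Cl)cc2)cc1` gives 92%. The step of a number 3.6 percentage points lower from compound 2 to compound 3 (within the scatter) shows that adding a hydroxy changed the read-out little. Compound 3 stands second highest of the three numbers; its gap to compound 2 lies within the scatter, while its gap to compound 1 lies beyond it. Compound 4 `COc1ccccc1C1=NN(c2ccc(Cl)cc2)C(c2ccc(O)cc2)C1` differs from compound 3 by methyl in place of hydrogen on an oxygen on an aromatic ring. Going by the values given here, no measured step exchanges hydrogen for methyl on an oxygen, so the only guide is that the one measured change on this same group stayed within the scatter. A similarly small shift in this assay is therefore expected, giving a number 4 percentage points lower from compound 3 to compound 4 (within the scatter). Compound 4 is expected to give 88%, between 70% and 98%.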

Compound 4, a percentage reported as inhibition, at one concentration (the size of the read-out at that concentration, not a potency): 68.4%
For compound 4 the middle estimate is 19.6 percentage points above the measured one, outside the stated range (below it).
By their numbers in this assay, from the lowest: compound 1; then compound 4; then compounds 3 and 2 (each within the scatter of the next).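

Going from 2-hydroxyphenyl to 2-methoxyphenyl gives a number 23.6 percentage points lower from compound 3 to compound 4 (beyond the scatter) in this assay, so this position, where hydrogen and hydroxy read alike, does respond to a methyl on the oxygen. Methoxy in place of hydrogen on the same aromatic carbon likewise gives a number 27.2 percentage points lower from compound 2 to compound 4 (beyond the scatter). No available measurement explains this drop.

On these data alone, whether a longer chain on that oxygen, such as ethoxy, would lower the number further remains open. So does the effect of an amine or a carboxylic acid on that aromatic carbon.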